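The source may hold more compounds than are shown below. What is called first, only, known or untested is meant among the compounds shown, and "the series" means these compounds.

Among the compounds with values here, in an assay on A7R5 cells for displacement of a labelled ligand from Endothelin-1 receptor (Rattus norvegicus) (on this read-out lower numbers stand for stronger inhibition and higher numbers for weaker inhibition), compound 1 `COc1cccc(Sc2c(NS(=O)(=O)c3ccc(C(C)(C)C)cc3)noc2CCCCC=O)c1` gives 1400 nM, the only number in the set so far. Compound 2 `CSc1c(NS(=O)(=O)c2ccc(C(C)(C)C)cc2)noc1C` returns a limit, > 100000 nM, which sits at the limit of > 100000 nM in this assay, at which 1 of the 3 values shown sits. Compound 3 `Cc1nsc(NS(=O)(=O)c2ccc(C(C)(C)C)cc2)c1C` likewise returns only a limit, > 500000 nM, which sits at the limit of > 500000 nM in this assay, at which 1 of the 3 values shown sits. Neither limit allows a step to compound 1 to be sized. Compound 4 `COc1cccc(Sc2c(NS(=O)(=O)c3ccc(C(C)(C)C)cc3)noc2CCCC(=O)O)c1` keeps the core of compound 1 and changes one place: carboxy in place of formylmethyl on a saturated chain carbon, three bonds along the chain from an aromatic carbon. Within the data shown here, no measured step of this kind stands in the set, so the size must be guessed; a modest gain, somewhat beyond the scatter, is expected, with weakening not excluded. For compound 4 the estimate in this assay is 700 nM, between 150 nM and 3500 nM. The expected step is a 2.0-fold lower number from compound 1 to compound 4 (0.30 log units; within the scatter).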

Compound 4, half-maximal inhibitory concentration: 4300 nM
The estimate for compound 4 lay 6.1-fold (0.79 log units) below the measured number, outside the stated range (above it).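

At the saturated chain carbon, three bonds along the chain from an aromatic carbon, the series now has its first readable step: in this assay, carboxy in place of formylmethyl gives a 3.1-fold higher number from compound 1 to compound 4 (0.49 log units; beyond the scatter), so this position responds to the change. Read as 4-formylbutyl to 3-carboxypropyl, the change alters both the chain end and the chain name's length. No measured property bears on the direction of this step.

The effects of chain end and chain length remain unseparated. A 4-carboxybutyl chain or an amine at the chain end would leave open different answers at this position.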